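Trifluoromethyl for methoxy on the urea phenyl

This account rests on a few compounds, and the source may have more. Where it says the series, first, only, none or still open, it means among the compounds named here.

Of the compounds shown here, three sharing one core have been measured in an assay on isolated protein for inhibition of serine/threonine-protein kinase PLK1 (Homo sapiens), read by radiometric assay and 33P incorporation, with a stated time of 40 min, tested at 20 uM, in the presence of a further agent that is not named here; on this read-out higher numbers stand for more inhibition at the one concentration tested (going by the name of the read-out) and lower numbers for less inhibition. Compound 1 `CCNc1cc(-c2ccc(NC(=O)Nc3ccc(C(F)(F)F)cc3)cc2C)ccn1` gives 54.8%. Compound 2 `CCNc1cc(-c2ccc(NC(=O)Nc3ccc(C(F)(F)F)cc3)cc2C(F)(F)F)ccn1`, which carries trifluoromethyl in place of methyl on an aromatic carbon, gives 82.9%, and that single change is a step of a number 28.1 percentage points higher from compound 1 to compound 2 (beyond the scatter). Compound 3 `CCNc1cc(-c2ccc(NC(=O)Nc3ccc(OC)cc3)cc2OC)ccn1` gives 31.1%, the lowest of the three numbers, and its distance to each of the other two lies beyond the scatter.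

Compound 4 `CCNc1cc(-c2ccc(NC(=O)Nc3ccc(C(F)(F)F)cc3)cc2OC)ccn1` is the next compound to be measured. It differs from compound 3 in one place: trifluoromethyl in place of methoxy on an aromatic carbon. Within the data shown here, the only measured step of a related kind is the one from compound 1 to compound 2, where trifluoromethyl also entered on an aromatic carbon and the inhibition rose by a modest amount. That step concerns a different place on the structure, so it bears on the present change only loosely. Compound 4 also shares its 4-(trifluoromethyl)phenyl urea with compounds 1 and 2, both of which sit well above compound 3. A rise beyond the scatter is therefore expected, and the step from compound 3 to compound 4 is estimated at a number 20.9 percentage points higher from compound 3 to compound 4 (beyond the scatter). Compound 4 is expected to give about 52%, within a range of 32% to 72% in this assay.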

Compound 4, a percentage reported as inhibition, at one concentration (the size of the read-out at that concentration, not a potency): 40.7%
Beside the measured number, compound 4's estimate is 11.3 percentage points above it, within the range that was stated.
By their numbers in this assay, from the lowest: compounds 3 and 4 (each within the scatter of the next); then compound 1; then compound 2.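

In this assay, the change from 4-methoxyphenyl to 4-(trifluoromethyl)phenyl gives a number 9.6 percentage points higher from compound 3 to compound 4 (within the scatter), so with methoxy held at the other varied site, this swap on the urea phenyl produces no clear shift in inhibition. The site where methyl, trifluoromethyl and methoxy alternate matters far more once the 4-(trifluoromethyl)phenyl urea is held constant: the data show a number 42.2 percentage points lower from compound 2 to compound 4 (beyond the scatter) and a number 14.1 percentage points lower from compound 1 to compound 4 (beyond the scatter), which adds methoxy as the lowest of the three groups at that site, below methyl and trifluoromethyl. No measurement is available that would explain either the small step on the urea phenyl or the larger steps at the other site.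

On these data alone, it remains open whether the change from 4-methoxyphenyl to 4-(trifluoromethyl)phenyl would stay this small with methyl or trifluoromethyl at the other site, since each compound here with a methyl or trifluoromethyl group at that site carries the same urea phenyl. How an amine or a carboxylic acid would read in place of trifluoromethyl on the urea phenyl also remains open, and a single-concentration percentage of this kind does not give the potency of any of these compounds.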